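From Trifluoromethyl to Ethoxycarbonyl: An Expected Small Step

This account rests on a few compounds, and the source may have more. Where it says the series, first, only, none or still open, it means among the compounds named here.

Of the compounds shown here, three sharing one core have been tested in an ADME assay on the whole organism with Oryza sativa as the target, tested at 0.1 uM; on this read-out higher numbers stand for a weaker effect at the one concentration tested and lower numbers for a stronger effect. Compound 1 `Cc1cccc(NC(=O)N[C@H](C)c2ccccc2)c1` gives 100%, compound 2 `CC(C)c1cccc(NC(=O)N[C@H](C)c2ccccc2)c1` gives 74%, and compound 3 `C[C@@H](NC(=O)Nc1cccc(C(F)(F)F)c1)c1ccccc1` gives 82%. Compound 3 thus sits between the other two, within the scatter of compound 2 and beyond it from compound 1. Compound 4 `CCOC(=O)c1cccc(NC(=O)N[C@H](C)c2ccccc2)c1` carries ethoxycarbonyl in place of trifluoromethyl on an aromatic carbon. Within the data shown here, no measured step makes this exact change, but both earlier replacements of the methyl group, a number 26 percentage points lower from compound 1 to compound 2 (beyond the scatter) and a number 18 percentage points lower from compound 1 to compound 3 (beyond the scatter), were modest drops, while a number 8 percentage points higher from compound 2 to compound 3 (within the scatter) stayed within the scatter. The step from compound 3 to compound 4 is therefore expected to be small, a number 4 percentage points lower from compound 3 to compound 4 (within the scatter), with no sure direction. Compound 4 is estimated at 78%, with an expected range from 58% to 100%.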

Compound 4, a percentage reported as activity, at one concentration (the size of the read-out at that concentration, not a potency): 99%
Compound 4: middle estimate off by 21 percentage points, on the low side; measured number inside the range.
By their numbers in this assay, from the lowest: compounds 2 and 3 (each within the scatter of the next); then compounds 4 and 1 (each within the scatter of the next).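

In this assay, ethoxycarbonyl does not behave like the two earlier replacements of methyl: trifluoromethyl gives way to it with a number 17 percentage points higher from compound 3 to compound 4 (beyond the scatter), the comparison with isopropyl shows a number 25 percentage points higher from compound 2 to compound 4 (beyond the scatter), and the comparison with methyl shows a number 1 percentage points lower from compound 1 to compound 4 (within the scatter). Replacing methyl at this position therefore does not always lower the number, with compound 4 going against what compound 2 and compound 3 show. Nothing available explains this difference. From the compounds shown here alone, it remains open whether a carboxylic acid or an amine here would resemble compound 4 or compound 2. Going by these compounds, it is equally open whether the ester's hydrogen-bond acceptors or its ethyl chain matter more.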